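Turning one ring centre of a sugar-like acid

The source may hold more compounds than are shown below. What is called first, only, known or untested is meant among the compounds shown, and "the series" means these compounds.

Compound 1 `O=C(O)[C@H]1NC[C@H](O)[C@H](O)[C@@H]1O` is a hydroxylated ring acid; in an assay on isolated protein for inhibition of cytosolic endo-beta-N-acetylglucosaminidase (Homo sapiens), tested at 1000 uM (on this read-out lower numbers stand for less inhibition and higher numbers for more inhibition at the one concentration tested (going by the name of the read-out)), compound 1 gives 26%, level with its mirror image compound 2 `O=C(O)[C@@H]1NC[C@@H](O)[C@@H](O)[C@H]1O`, which gives 26%, and together these are the highest of the three numbers. Compound 3 `O=C(O)[C@H]1NC[C@H](O)[C@@H](O)[C@H]1O` gives 2.6%. Compound 4 `O=C(O)[C@H]1NC[C@@H](O)[C@H](O)[C@@H]1O` differs from compound 1 only in configuration: the two compounds have the same atoms and bonds and differ only in configuration as drawn: 1 of 4 stereo elements differ; a stereocentre at a saturated ring carbon is drawn S in compound 1 and R in compound 4. Among the compounds with values here, no measured step inverts a single centre, but no change at the digits printed from compound 1 to compound 2 (within the scatter) whereas a number 23.4 percentage points lower from compound 1 to compound 3 (beyond the scatter), so changing part of the configuration can lower the number. A modest drop from compound 1 to compound 4 is therefore expected, a number 14 percentage points lower from compound 1 to compound 4 (beyond the scatter). Compound 4 is estimated at 12%, expected between 0% and 30%.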

Compound 4, a percentage reported as inhibition, at one concentration (the size of the read-out at that concentration, not a potency): 42%
The estimate for compound 4 lay 30 percentage points below the measured number; measured number outside the range, above it.
By their numbers in this assay, from the lowest: compound 3; then compounds 1 and 2 (each within the scatter of the next); then compound 4.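

Inverting this one ring centre, with atoms and bonds unchanged, gives a number 16 percentage points higher from compound 1 to compound 4 (beyond the scatter) in this assay. A change of configuration can therefore raise the number as well as lower it, and this centre matters on its own. The wider steps, a number 16 percentage points higher from compound 2 to compound 4 (beyond the scatter) and a number 39.4 percentage points higher from compound 3 to compound 4 (beyond the scatter), each change three centres at once, so neither can be tied to a single centre.

On these data alone, it stays open how inverting each other centre alone would move the number. As far as these compounds go, what an amide in place of the carboxylic acid would do also remains unknown.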